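Methyl on the ring amide nitrogen: compound 2 to compound 3

A few compounds are considered here, and "the series" means these few. Any claim that something is new, unique, unknown or untested is made for them only; others in the source may bear on it.

Measured so far:
compound 1, `CN1C/C(=C\c2ccccc2)C(=O)[C@]2(C1)[C@@H](c1ccccc1)CN(C)[C@@]21C(=O)Nc2ccccc21`, 77%
compound 2, `CN1C/C(=C\c2ccc(-c3cccs3)cc2)C(=O)[C@]2(C1)[C@@H](c1ccc(-c3cccs3)cc1)CN(C)[C@@]21C(=O)Nc2ccccc21`, 68%

In a functional assay on the whole organism (strain Wister albino) for inhibition, with Rattus norvegicus as the target, read by paw edema, with a stated time of 1 h, at a dose of 50 mg/kg by the intraperitoneal route (a lower number here means less inhibition, a higher number more inhibition at the dose given (going by the name of the read-out)), compound 1 gives 77%. In this assay compound 2 gives 68%. Compound 2 stands at the lower of the two numbers, with compound 1 lying within the scatter of it, so the two are not separated by this measurement.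

Compound 3 is `CN1C/C(=C\c2ccc(-c3cccs3)cc2)C(=O)[C@]2(C1)[C@@H](c1ccc(-c3cccs3)cc1)CN(C)[C@@]21C(=O)N(C)c2ccccc21`. It differs from compound 2 in one place: methyl in place of hydrogen on an amide-type nitrogen in a ring. Going by the values given here, no step between two measured compounds shows what this kind of change does in this assay, so the direction is not known from the data. Among the compounds with values here, for a change of one heavy atom on an amide-type nitrogen in a ring of the shared core, with nothing among the measured pairs to weigh it, a step no larger than the scatter is expected, in either direction.

For compound 3 in this assay the estimate is 64%, with a range from 50% to 78%. The step this estimate means, a number 4 percentage points lower from compound 2 to compound 3 (within the scatter), is expected to lie within the scatter.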

Compound 3, a percentage reported as inhibition, in the whole organism at one dose (the size of the read-out at that dose, not a potency): 84.7%
The estimate for compound 3 lay 20.7 percentage points below the measured number; measured number outside the range, above it.
By their numbers in this assay, from the lowest: compounds 2, 1 and 3 (each within the scatter of the next, the first and the last beyond it).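

Going by these compounds alone, until now no step at this position could be read, and the single pair gives it a first direction: in this assay methyl in place of hydrogen on the amide-type nitrogen gives a number 16.7 percentage points higher from compound 2 to compound 3 (beyond the scatter) and so goes beyond the usual spread of repeated measurements. Removing the amide hydrogen therefore does not cost inhibition at the dose given in this pair, and this one added carbon on the shared core is enough to move the read-out upward, although the step is a modest one. Nothing measured here gives a reason for the rise, so the result stands as an observation on this pair alone.

On these data alone, it remains open whether the same methyl would produce a similar step on compound 1, since this change has been read only on compound 2 and at a single dose and time. As far as these compounds go, it is also open how a longer chain such as ethyl, a benzyl group or an acetyl group on this nitrogen would compare with methyl and with the amide hydrogen.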